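The source may hold more compounds than are shown below. What is called first, only, known or untested is meant among the compounds shown, and "the series" means these compounds.

Measured so far in a functional assay on HCT-116 cells (Homo sapiens) for antiproliferative activity, read by MTT assay, with a stated time of 24 h; a lower number here means a stronger inhibitor, a higher number a weaker inhibitor:

- compound 1 `COc1cc(OC)c(-c2coc3cc(OCC=C(C)C)ccc3c2=O)cc1OC`: 680 nM
- compound 2 `C=CCOc1ccc2c(=O)c(-c3cc(OC)c(OC)cc3OC)coc2c1`: 6600 nM
- compound 3 `COc1cc(OC)c(-c2coc3cc(OCc4ccc(F)cc4)ccc3c2=O)cc1OC`: 950 nM

Compound 3, at 950 nM, stands level with compound 1 within the scatter, a 1.4-fold higher number from compound 1 to compound 3 (0.15 log units; within the scatter). It lies well clear of compound 2, a 6.9-fold lower number from compound 2 to compound 3 (0.84 log units; beyond the scatter).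

The next compound is compound 4 `COc1cc(OC)c(-c2coc3cc(OCc4ccccc4C#N)ccc3c2=O)cc1OC`, which takes 2-cyanophenyl in place of 4-fluorophenyl on the saturated chain carbon bound to an oxygen on an aromatic ring: 2-cyanophenyl in place of 4-fluorophenyl on a saturated chain carbon bound to an oxygen on an aromatic ring.

Three measured steps change this same place. The two large ones, a 9.7-fold higher number from compound 1 to compound 2 (0.99 log units; beyond the scatter) and a 6.9-fold lower number from compound 2 to compound 3 (0.84 log units; beyond the scatter), both involve the vinyl group of compound 2. The exchange of 2-methylprop-1-en-1-yl for 4-fluorophenyl, a 1.4-fold higher number from compound 1 to compound 3 (0.15 log units; within the scatter), stayed within the scatter. For the measured compounds named here, no measured step replaces 4-fluorophenyl with a related group, so the evidence here is indirect. Compound 4 keeps a phenyl at this place, as compound 3 does, so no shift beyond the scatter is expected in this assay.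

The expected change is a 1.1-fold higher number from compound 3 to compound 4 (0.02 log units; within the scatter).

For compound 4 the estimated value is 1000 nM, with an expected range from 350 nM to 3000 nM.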

Compound 4, half-maximal inhibitory concentration: > 10000 nM
Compound 4: only a limit was reported; the forecaster's own chance of this, stated with the estimate: 3%; middle value at least 10-fold (1.00 log units) away from the limit.
By their numbers in this assay, from the lowest: compounds 1 and 3 (each within the scatter of the next); then compound 2. At a limit, above all of these: compound 4.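

In this assay, compound 4 gave only a limit of the assay, not a number: the limit of > 10000 nM in this assay, at which 1 of the 4 values shown sits. The change from 4-fluorobenzyl to 2-cyanobenzyl gives an at least 10-fold higher number from compound 3 to compound 4 (1.02 log units; beyond the scatter), so keeping an aromatic ring at this place does not by itself keep the activity, and what the ring carries matters. Against the 2-methylprop-1-en-1-yl group the gap is an at least 14-fold higher number from compound 1 to compound 4 (1.16 log units; beyond the scatter), while an at least 1.5-fold higher number from compound 2 to compound 4 (0.18 log units; that floor lies within the scatter) leaves it unsettled whether compound 4 truly differs from the small vinyl compound.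

The compounds shown change both the substituent on the ring and its place on the ring at once, so it stays open which of the two goes with the loss. Plain benzyl, 4-cyanobenzyl and 2-fluorobenzyl at this place would separate these two changes.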